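Methylsulfonyl for hydroxyisopropyl on a benzofuran ether series

The source may hold more compounds than are shown below. What is called first, only, known or untested is meant among the compounds shown, and "the series" means these compounds.

Of the compounds shown here, three sharing one core have been measured in an ADME assay on the whole organism (Rattus norvegicus), at a dose of 2 mg/kg by the oral route; on this read-out lower numbers stand for lower exposure and higher numbers for higher exposure at the dose given. Compound 1 `COc1cc(OCc2csc(-c3ccc(C(C)(C)O)cc3)n2)c2cc(-c3cn4nc(OC)sc4n3)oc2c1` gives 505 ng.h/mL. Compound 2 `COc1cc(OCc2cccc(-c3cnc(OC)nc3)c2)c2cc(-c3cn4nc(OC)sc4n3)oc2c1` gives 1030 ng.h/mL, and compound 3 `COc1cc(OCc2cccc(-c3cnc(OC)cn3)c2)c2cc(-c3cn4nc(OC)sc4n3)oc2c1` gives 722 ng.h/mL. For the measured compounds named here, the only single-point step among them, a 1.4-fold lower number from compound 2 to compound 3 (0.15 log units; within the scatter), lies within the scatter. Compound 1 stands apart only from compound 2, whose number is beyond the scatter of it; against compound 3 the two values lie within the scatter of one another.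

Compound 4 `COc1cc(OCc2csc(-c3ccc(S(C)(=O)=O)cc3)n2)c2cc(-c3cn4nc(OC)sc4n3)oc2c1` differs from compound 1 in one place: methylsulfonyl in place of 1-hydroxy-1-methylethyl on an aromatic carbon. Going by the values given here, no measured step concerns this change. Among the compounds with values here, the one step that exists, from compound 2 to compound 3, swaps a heteroaryl ring elsewhere on the molecule and was itself within the scatter, so it gives no direction for the present exchange. With nothing to lean on, the expectation for this assay is a step of no size beyond the scatter, in either direction, and the range is kept broad to reflect that.

Compound 4 is therefore estimated at 500 ng.h/mL, with a range from 200 ng.h/mL to 1250 ng.h/mL. The step this implies, a 1.0-fold lower number from compound 1 to compound 4 (0.00 log units; within the scatter), is expected to fall within the scatter.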

Compound 4, area under the concentration-time curve: 148 ng.h/mL
Estimate against measurement, compound 4: 3.4-fold (0.53 log units) above; the measured number lies below the stated range.
By their numbers in this assay, from the lowest: compound 4; then compounds 1, 3 and 2 (each within the scatter of the next, the first and the last beyond it).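

In this assay, for the compounds shown here, putting methylsulfonyl in place of 1-hydroxy-1-methylethyl on the six-membered aromatic ring of carbon only, para to a large group, gives a 3.4-fold lower number from compound 1 to compound 4 (0.53 log units; beyond the scatter), so this position is not indifferent to the group it carries, something the earlier compounds could not show. The two groups have the same heavy-atom count, so that count does not separate them; they differ in their atoms and in their hydrogen-bond donors and acceptors, and the hydroxyl hydrogen-bond donor of compound 1 is absent from compound 4. Nothing available here explains why the number drops with this exchange.

Still open, on these data alone, is whether the step follows the loss of the hydroxyl group or the arrival of the sulfonyl group, a question that a primary carboxamide, a methoxy group or a hydroxymethyl group at the same place could help to settle. Going by these compounds alone, also open is whether the same exchange would move the number as far on a different arm of the shared core, such as the one carried by compound 2 or compound 3.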